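Swapping the Ester for a Methoxy Group on a Urea

This account rests on a few compounds, and the source may have more. Where it says the series, first, only, none or still open, it means among the compounds named here.

Measured compounds:
compound 1, `CC(C)c1cccc(NC(=O)N[C@@H](C)c2ccccc2)c1`: 84%
compound 2, `CCOC(=O)c1cccc(NC(=O)N[C@@H](C)c2ccccc2)c1`: 99%

Both compounds share the same urea core and differ only in one group on an aromatic carbon. In an ADME assay on the whole organism with Oryza sativa as the target, tested at 1 uM (on this read-out lower numbers stand for a stronger effect and higher numbers for a weaker effect at the one concentration tested), compound 1 gives 84%, while compound 2 gives 99%. For the measured compounds named here, of the two numbers, the one for compound 2 is the highest, meaning the weakest effect seen so far. Going by the values given here, the only step available is a number 15 percentage points higher from compound 1 to compound 2 (beyond the scatter), and it goes beyond the usual scatter.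

Compound 3, `COc1cccc(NC(=O)N[C@@H](C)c2ccccc2)c1`, has not yet been measured. It differs from compound 2 in one place: methoxy in place of ethoxycarbonyl on an aromatic carbon. Among the compounds with values here, no measured step involves a methoxy group, so the single known step is only an indirect guide: it shows that exchanging the group at this aromatic carbon can shift the read-out by a modest amount. Since compound 2 already sits near the top of the scale, a small downward move or none beyond the scatter is expected, estimated as a number 9 percentage points lower from compound 2 to compound 3 (within the scatter). Compound 3 is therefore expected to give about 90%, with a range from 75% to 100%.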

Compound 3, a percentage reported as activity, at one concentration (the size of the read-out at that concentration, not a potency): 99%
Compound 3: middle estimate off by 9 percentage points, on the low side; measured number inside the range.
By their numbers in this assay, from the lowest: compound 1; then compounds 2 and 3 (each within the scatter of the next).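

In this assay, the step of no change at the digits printed from compound 2 to compound 3 (within the scatter) shows that ethoxycarbonyl, with 5 heavy atoms, can give way to methoxy, with 2 heavy atoms, with no shift beyond the scatter, so this much smaller group gives a read-out that cannot be told apart from that of the larger one. The step of a number 15 percentage points higher from compound 1 to compound 3 (beyond the scatter) adds a second comparison with isopropyl: among these three compounds, compound 1 now stands apart from two different groups rather than one, and it alone has the lower number beyond the scatter. No supporting measurement is available to explain why these groups compare as they do.

The compounds shown leave open whether the lower number of compound 1 is specific to isopropyl or would also appear with another group built only of carbon and hydrogen, such as tert-butyl or a longer alkyl chain. They also leave open how an amine or a carboxylic acid at this aromatic carbon would read out in this assay, and whether either would match compound 1 or stay with compounds 2 and 3.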